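Adding a Second Methoxy Group to a Nitrophenyl Enone

This account rests on a few compounds, and the source may have more. Where it says the series, first, only, none or still open, it means among the compounds named here.

The measured compounds and their values:
Compound 1 `CC(=O)OC/C(=C\c1ccccc1F)C(=O)c1ccccc1` gives 68700 nM in a functional assay on A549 cells (Homo sapiens) for inhibition, read by XTT assay, with a stated time of 48 h; on this read-out lower numbers stand for stronger inhibition and higher numbers for weaker inhibition.
Compound 2 `COc1ccc(C(=O)/C(=C/c2ccccc2F)COC(C)=O)cc1` gives 22500 nM in this assay.
Compound 3 `C=C(C(=O)c1ccc(OC)cc1)C(OC(C)=O)c1ccc([N+](=O)[O-])cc1` gives 21300 nM in this assay.

Compound 1 and compound 2 differ by one change, (methoxy in place of hydrogen on an aromatic carbon), and this gave a 3.1-fold lower number from compound 1 to compound 2 (0.48 log units; beyond the scatter). Compound 3 shares the methoxy-bearing ring of compound 2 but carries a different core; the difference between the two cores is not broken down here. The values of compound 2 and compound 3 lie within the usual scatter of each other, so no order can be drawn between them.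

Compound 4 `C=C(C(=O)c1ccc(OC)cc1OC)C(OC(C)=O)c1ccc([N+](=O)[O-])cc1` has not yet been measured. It differs from compound 3 by methoxy in place of hydrogen on an aromatic carbon. This is the same kind of change as that from compound 1 to compound 2, but not the same: there the methoxy entered para to a large group, here it enters ortho to a large group and meta to a methoxy group. Because the earlier change gave a 3.1-fold lower number from compound 1 to compound 2 (0.48 log units; beyond the scatter), a lower number for compound 4 than for compound 3 is expected, but a smaller step is estimated, a 1.5-fold lower number from compound 3 to compound 4 (0.18 log units; within the scatter), since the place differs. Compound 4 is therefore expected to give about 14000 nM, with a range from 6000 nM to 35000 nM.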

Compound 4, half-maximal inhibitory concentration: 43500 nM
Beside the measured number, compound 4's estimate is 3.1-fold (0.49 log units) below it, and the stated range ends below it.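

In this assay, the added methoxy went the opposite way this time, giving a 2.0-fold higher number from compound 3 to compound 4 (0.31 log units; beyond the scatter). Set beside the earlier step, the same change did not carry over from one core to the other: the same change on two cores in this assay, a 3.1-fold lower number (0.48 log units; beyond the scatter) from compound 1 to compound 2 and a 2.0-fold higher number (0.31 log units; beyond the scatter) from compound 3 to compound 4, 6.2-fold (0.79 log units) apart, beyond the scatter of two such steps. This shows that, in this series, the effect of adding a methoxy to one compound is a poor guide to its effect on another, but it does not show why, as the two steps differ both in the core and in where the methoxy enters, each step rests on a single pair of compounds, and the two differences cannot be told apart here.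

On these data alone, it remains open whether a methoxy ortho to a large group would also raise the number on the core of compound 1, which would point to the place rather than the core. Also open, as far as these compounds go, is whether an amine or an ethoxy group in that same place would follow the methoxy.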